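This account rests on a few compounds, and the source may have more. Where it says the series, first, only, none or still open, it means among the compounds named here.

Compound 1 `O=C1C(=O)N(Cc2ccc(-c3ccncc3)cn2)c2ccc(OC(F)(F)F)cc21` and compound 2 `O=C1C(=O)N(Cc2ccc(-c3ccccc3)cn2)c2ccc(OC(F)(F)F)cc21` share one core and differ only in the aryl group at its end. In a functional assay on CHO cells for positive allosteric modulation of muscarinic acetylcholine receptor M5 (Homo sapiens), read by FLIPR and calcium flux, with a stated time of 1 h (a higher number here means that more compound is needed for the effect, a lower number that less compound is needed), compound 1 reaches only the limit of the measurement, > 30000 nM. Compound 2 gives 3100 nM in this assay, and the step of an at least 9.6-fold lower number from compound 1 to compound 2 (0.98 log units; beyond the scatter) shows how much the phenyl changes the picture. Compound 3 `O=C1C(=O)N(Cc2ccc(-c3ccccc3)cc2F)c2ccc(OC(F)(F)F)cc21`, which carries the phenyl on a fluorinated ring, gives 5900 nM in this assay. Among the two numbers that are not limits, compound 2 holds the lowest, with compound 3 within the scatter of it; the third value is a limit (the limit of > 30000 nM in this assay, at which 1 of the 3 values shown sits).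

Compound 4 `O=C1C(=O)N(Cc2ccc(-c3cccnc3)cn2)c2ccc(OC(F)(F)F)cc21` arises from compound 2 by the change (pyridin-3-yl in place of phenyl on an aromatic carbon). Among the compounds with values here, the only measured step that bears on it is an at least 9.6-fold lower number from compound 1 to compound 2 (0.98 log units; beyond the scatter), where a pyridyl in place of the phenyl meant a markedly higher number. The new pyridyl is attached at a different ring carbon, so the same size is not certain, but a rise is expected. Compound 4 is therefore estimated at 15000 nM in this assay, within 5000 nM to 60000 nM, an expected step of a 4.8-fold higher number from compound 2 to compound 4 (0.68 log units; beyond the scatter).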

Compound 4, half-maximal effective concentration: > 30000 nM
Compound 4 ended at the assay's limit; the forecaster's own chance of this, stated with the estimate: 35%; at least 2.0-fold (0.30 log units) between middle value and limit.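

Replacing the phenyl with pyridin-3-yl gives an at least 9.6-fold higher number from compound 2 to compound 4 (0.98 log units; beyond the scatter) and thus a loss as clear as the one seen with pyridin-4-yl, so that loss is not tied to a single pyridyl attachment. On this core and at this place, phenyl in compound 2 is the only one of the three aryl groups in this assay with a value that is not a limit. The step between compound 1 and compound 4 cannot be read, so the two pyridyl groups remain unordered: the limit of > 30000 nM in this assay, at which 2 of the 4 values shown sit.

The compounds shown leave open whether any other group at this place, such as a pyrimidin-5-yl ring or a phenyl carrying a methoxy group or a chlorine, would match or lower the number given by phenyl. They also leave open how a pyridin-2-yl group would behave here.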